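Shortening the Chain Between Amide and Phenyl Ring

A few compounds are considered here, and "the series" means these few. Any claim that something is new, unique, unknown or untested is made for them only; others in the source may bear on it.

Two compounds share one core and differ at a single point. Compound 1 `O=C(CCCc1ccccc1)Nc1nc2cc(Cl)ccc2c(=O)s1` carries a chloro group on an aromatic carbon, and in an assay on CHO cells for displacement of a labelled ligand from adenosine receptor A1 (Homo sapiens), read by scintillation counting, with a stated time of 90 min (on this read-out lower numbers stand for stronger inhibition and higher numbers for weaker inhibition), compound 1 gives 785 nM. Compound 2 `O=C(CCCc1ccccc1)Nc1nc2ccccc2c(=O)s1` has hydrogen in place of that chloro, and in this assay compound 2 gives 2500 nM. Within the data shown here, the only measured step, a 3.2-fold higher number from compound 1 to compound 2 (0.50 log units; beyond the scatter), is modest but beyond the scatter. Among the measured compounds shown here, on the two numbers so far, compound 2 stands at the higher, weaker end, with compound 1 as its only and nearer neighbour at the lower number.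

Compound 3 `O=C(CCc1ccccc1)Nc1nc2ccccc2c(=O)s1` keeps the unsubstituted core of compound 2 and alters the amide side chain instead: phenyl in place of benzyl on a saturated chain carbon, two bonds along the chain from a carbonyl carbon. For the measured compounds named here, no measured step touches this part of the molecule; the step from compound 1 to compound 2 concerns the aromatic chloro and says nothing about the chain. Without a guide, no step beyond the scatter is expected in this assay in either direction, though the uncertainty is wide. For compound 3 the estimate in this assay is 3000 nM, between 800 nM and 12000 nM. That estimate for compound 3 is expected to mean a 1.2-fold higher number from compound 2 to compound 3 (0.08 log units; within the scatter).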

Compound 3, inhibition constant: 1050 nM
Estimate against measurement, compound 3: 2.9-fold (0.46 log units) above; the range from low to high includes it.
By their numbers in this assay, from the lowest: compounds 1 and 3 (each within the scatter of the next); then compound 2.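

Among these compounds, this is the first measured change to the amide side chain, and it shows that this part of the molecule affects the number in this assay and is not a silent position. With phenyl in place of benzyl on a saturated chain carbon, two bonds along the chain from a carbonyl carbon, the chain is shorter and the result is a 2.4-fold lower number from compound 2 to compound 3 (0.38 log units; beyond the scatter), a modest gain in inhibition for the shorter chain of this pair. No measurement at hand explains why this change moves the number.

Going by these compounds, two chain lengths give a direction but not a trend, so it remains open how a still shorter chain, or a chain longer than that of compound 2, would read in this assay, and whether the gain would also appear on the chloro-bearing core of compound 1. The compounds shown also say nothing about what other groups at the end of the chain, such as a cyclohexyl ring or a carboxylic acid, would do in place of the phenyl ring.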